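Alpha-Hexyl Branch on an Aryloxy-Alkanoic Acid

A few compounds are considered here, and "the series" means these few. Any claim that something is new, unique, unknown or untested is made for them only; others in the source may bear on it.

Compound 1 `Cc1ccc(C)c(OCCCCC(=O)O)c1`: 707000 nM
Compound 2 `Cc1ccc(C)c(OCCCCCC(=O)O)c1`: 389000 nM

These two values come from an assay on Sf9 cells for activation of soluble guanylate cyclase alpha1/beta1 complex (Homo sapiens), read by cGMP accumulation, with a stated time of 15 min; a higher number here means that more compound is needed for the effect, a lower number that less compound is needed. Within the data shown here, compound 1 has the highest of the two numbers, but its only neighbour is compound 2, and the single measured step, a 1.8-fold lower number from compound 1 to compound 2 (0.26 log units; within the scatter), lies within the scatter, so the two compounds cannot be told apart in this assay.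

Compound 3 `CCCCCCC(CCCOc1cc(C)ccc1C)C(=O)O` is not yet measured. It differs from compound 1 in one place: hexyl in place of hydrogen on a saturated chain carbon bound to a carbonyl carbon and a saturated chain carbon. Among the measured compounds shown here, no measured step touches that carbon; the only step known, from carboxy to carboxymethyl, changes the acid end itself and was within the scatter. The expectation for compound 3 therefore rests on little more than the pair shown. A chain of six carbons entering at the carbon next to the carbonyl is a larger change than the one measured, so a real shift in this assay is possible in either direction, and the range must be wide.

Compound 3 is expected to give 250000 nM in this assay, between 50000 nM and 1000000 nM, an estimated step of a 2.8-fold lower number from compound 1 to compound 3 (0.45 log units; beyond the scatter).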

Compound 3, half-maximal effective concentration: 128000 nM
For compound 3 the middle estimate is 2.0-fold (0.29 log units) above the measured one, within the range that was stated.
By their numbers in this assay, from the lowest: compound 3; then compounds 2 and 1 (each within the scatter of the next).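

In this assay, among these compounds, the hexyl branch gives a 5.5-fold lower number from compound 1 to compound 3 (0.74 log units; beyond the scatter) and so provides the first change in this set that can be told apart from the scatter. The earlier step, a 1.8-fold lower number from compound 1 to compound 2 (0.26 log units; within the scatter), altered the acid end and left the two compounds indistinguishable, whereas this one shows that the saturated chain carbon bound to a carbonyl carbon and a saturated chain carbon accepts hexyl in place of hydrogen and that the number falls rather than rises, with compound 3 at 128000 nM still in the same high range of concentrations as the other two compounds. Nothing available bears on the reason for this shift.

The compounds shown leave open whether the effect follows the length of the branch, since a methyl, a butyl or an octyl group on the same carbon would be needed to trace any such trend, and whether a chain is required at all could be tested with a benzyl group there. They also leave open whether the hexyl branch acts in the same way on the core of compound 2, with its carboxymethyl end.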